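A few compounds are considered here, and "the series" means these few. Any claim that something is new, unique, unknown or untested is made for them only; others in the source may bear on it.

Measured in an ADME assay on TERT-RPE1 cells (Homo sapiens) for cytotoxicity, read by MTT assay, with a stated time of 72 h; a lower number here means a stronger inhibitor, a higher number a weaker inhibitor:
- Compound 1 `COc1ccc(/C=C2\S/C(=N\c3ccc(C)c(Cl)c3)N(C)C2=O)cc1`: 23000 nM.
- Compound 2 `COc1ccc(/C=C2\S/C(=N\c3ccc(Br)cc3)N(C)C2=O)cc1`: > 100000 nM, a limit.
- Compound 3 `COc1ccc(/C=C2\S/C(=N\c3c(C)cccc3C)N(C)C2=O)cc1`: > 100000 nM, a limit.

Compound 3 has no number, only a limit. It stands at the limit of > 100000 nM in this assay, at which 2 of the 3 values shown sit.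

Compound 4 `COc1ccc(/C=C2\S/C(=N\c3ccc(C)cc3)N(C)C2=O)cc1` carries 4-methylphenyl in place of 2,6-dimethylphenyl on a double-bonded nitrogen.

The nearest evidence is an at least 4.3-fold higher number from compound 1 to compound 2 (0.63 log units; beyond the scatter) and an at least 4.3-fold higher number from compound 1 to compound 3 (0.63 log units; beyond the scatter). Both are bounds, and a step that the two limits leave unreadable from compound 2 to compound 3 adds no size. The entering 4-methylphenyl resembles the 4-bromophenyl of compound 2 more than the 3-chloro-4-methylphenyl of compound 1, so a result near the limit is expected, with a modest drop at most in this assay.

The expected change is an at least 1.2-fold lower number from compound 3 to compound 4 (0.09 log units; that floor lies within the scatter).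

Compound 4 is estimated at 80000 nM, with an expected range of 30000 nM to 200000 nM.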

Compound 4, half-maximal inhibitory concentration: > 100000 nM
Compound 4 ended at the assay's limit; the forecaster's own chance of this, stated with the estimate: 55%; middle value at least 1.2-fold (0.09 log units) away from the limit.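

In this assay, hydrogen in place of chloro on an aromatic carbon gives an at least 4.3-fold higher number from compound 1 to compound 4 (0.63 log units; beyond the scatter), so at this position the measurable cytotoxicity depends on the chloro being present alongside the methyl. The steps among compound 2, compound 3 and compound 4 cannot be read, as all three values are limits. Compound 4 has only a limit, and it joins the others there: the limit of > 100000 nM in this assay, at which 3 of the 4 values shown sit.

From the compounds shown here alone, whether chloro without the methyl would give a number short of the limit remains open. Going by these compounds, the effect of an amine or a carboxylic acid in place of that chloro is also open.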